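Chloro in Place of Bromo: Compound 1 to Compound 4

The compounds below may be only part of what the source reports. "The series", "measured", "known", "first", "only" and "open" are said of these compounds alone.

Compound 1 `Cc1ccc(S/C(=C/c2ccc(Br)cc2)C(=O)c2ccc(Cl)cc2)cc1` gives 25000 nM in a functional assay on DU-145 cells (Homo sapiens) for inhibition, read by trypan blue exclusion, with a stated time of 96 h (a higher number here means a weaker inhibitor of growth, a lower number a stronger inhibitor of growth), the highest of the three numbers measured; compound 2 `Cc1ccc(CS(=O)(=O)/C(=C/c2ccc(S(C)(=O)=O)cc2)C(=O)c2ccc(Br)cc2)cc1` gives 10000 nM, and compound 3 `O=C(/C(=C\c1ccc(Br)cc1)SCc1ccc(Cl)cc1)c1ccc(Cl)cc1` gives 1000 nM. Among the compounds with values here, the single step between measured compounds that differ in one place, a 25-fold lower number from compound 1 to compound 3 (1.40 log units; beyond the scatter), concerns a change on the sulfur and does not touch the position altered here. Compound 4 `Cc1ccc(S/C(=C/c2ccc(Cl)cc2)C(=O)c2ccc(Cl)cc2)cc1` differs from compound 1 as follows: chloro in place of bromo on an aromatic carbon. Within the data shown here, no measured pair shows this exchange, so nothing in the data argues for a shift beyond the scatter in this assay. The expected step is a 1.3-fold lower number from compound 1 to compound 4 (0.10 log units; within the scatter), within the scatter. Compound 4 is estimated at 20000 nM, with a range from 8000 nM to 50000 nM.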

Compound 4, concentration for 50% growth inhibition: 10000 nM
The estimate for compound 4 lay 2.0-fold (0.30 log units) above the measured number; the measured number falls inside the stated range.
By their numbers in this assay, from the lowest: compound 3; then compounds 2 and 4 (each within the scatter of the next); then compound 1.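

Within the data shown here, replacing 4-bromophenyl with 4-chlorophenyl, the first change at this position that can be read in this assay, gives a 2.5-fold lower number from compound 1 to compound 4 (0.40 log units; beyond the scatter). The number thus responds to which halogen sits here, although this step is smaller than a 25-fold lower number from compound 1 to compound 3 (1.40 log units; beyond the scatter), which came from the change on the sulfur. Nothing at hand gives a reason for this step.

On these data alone, whether an amine or a methoxy group at this position would move the number further remains open. As far as these compounds go, it is also open whether chloro in place of bromo gives a similar step in compound 3, with its 4-chlorobenzyl on the sulfur.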